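Semicarbazone series: methoxy for methyl on the aryl arm

The source may report more compounds than this note shows. Statements on the series, on what has been measured and on what is new or still open speak of the compounds shown alone.

Measured so far:
compound 1 `COc1ccc(-c2cc(-c3ccc(F)cc3)nc(NC(=O)N/N=C\c3ccccc3[N+](=O)[O-])n2)c(OC)c1`; in a functional assay on the whole organism (strain Albino) with Mus musculus as the target, with a stated time of 4 h (on this read-out higher numbers stand for an effect only at larger amounts of compound and lower numbers for an effect already at smaller amounts), compound 1 gives 300 mg/kg
compound 2 `C/C(=N/NC(=O)Nc1nc(-c2ccc(F)cc2)cc(-c2ccc([N+](=O)[O-])cc2)n1)c1ccc(C)cc1`; in this assay compound 2 gives 300 mg/kg

On these numbers compound 2 stands level with compound 1 at the digits shown; the two values lie within the scatter of each other, so no order between them is claimed. Compound 3 `COc1ccc(/C(C)=N\NC(=O)Nc2nc(-c3ccc(F)cc3)cc(-c3ccc([N+](=O)[O-])cc3)n2)cc1` differs from compound 2 in one place: methoxy in place of methyl on an aromatic carbon. Within the data shown here, no pair of measured compounds separated by a single change is available, so the size of such a step has not been seen. In this assay the expected step from compound 2 to compound 3 is no change at the digits printed from compound 2 to compound 3 (within the scatter), that is, nothing beyond the scatter. Compound 3 is accordingly expected at 300 mg/kg, within a range from 150 mg/kg to 600 mg/kg.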

Compound 3, dose for half-maximal effect: 300 mg/kg
Beside the measured number, compound 3's estimate shows no gap at the digits printed, and the stated range covers the measured number.
By their numbers in this assay, from the lowest: compounds 1, 2 and 3 (each within the scatter of the next).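

Among these compounds, the change from 4-methylphenyl to 4-methoxyphenyl gives the first single-change step in this assay, and it reads no change at the digits printed from compound 2 to compound 3 (within the scatter). Compound 1 and compound 2 differ in more than one place and could not show this, whereas here one change on an aromatic carbon, para to a large group, adds an oxygen and a hydrogen-bond acceptor with no step beyond the scatter. Nothing available bears on the reason for this result.

As far as these compounds go, whether this place accepts other groups equally remains open, since an amine, a carboxylic acid or a longer chain such as ethoxy could give a different step. From the compounds shown here alone, it is also open whether methoxy in place of methyl gives the same step on another aryl arm of the shared core.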